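Back from a basic side chain to a plain dialkylamino

The source may report more compounds than this note shows. Statements on the series, on what has been measured and on what is new or still open speak of the compounds shown alone.

The measured compounds:
compound 1 `Cc1cc(N(C)C)nc2ccc(NC(=O)c3ccc(Cl)c(Cl)c3)cc12` gives > 50000 nM in a functional assay on SK-BR-3 cells (Homo sapiens) for antiproliferative activity, read by MTT assay, with a stated time of 72 h (on this read-out higher numbers stand for weaker inhibition and lower numbers for stronger inhibition), which is a limit of the assay.
compound 2 `CCN1CCN(c2cc(C)c3cc(NC(=O)c4ccc(F)cc4)ccc3n2)CC1` gives 19800 nM in this assay.
compound 3 `Cc1cc(NCCN2CCCC2)nc2ccc(NC(=O)c3ccc(Cl)c(Cl)c3)cc12` gives 9530 nM in this assay.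

Compound 3 stands lowest of the two numbers shown in this assay; the nearest is compound 2, whose 19800 nM is beyond the scatter above it. Compound 1 sits only at the limit (the limit of > 50000 nM in this assay, at which 1 of the 3 values shown sits).

Compound 4 `CCN(CC)c1cc(C)c2cc(NC(=O)c3ccc(Cl)c(Cl)c3)ccc2n1` differs from compound 3 in one place: diethylamino in place of (2-(pyrrolidin-1-yl)ethyl)amino on an aromatic carbon. For the measured compounds named here, one measured step bears on it: an at least 5.2-fold lower number from compound 1 to compound 3 (0.71 log units; beyond the scatter), which went the other way, from dimethylamino to the (2-(pyrrolidin-1-yl)ethyl)amino group now being removed. Diethylamino stands nearer to the dimethylamino of compound 1 than to that side chain, so the step is expected to run back toward the limit, with a higher number, likely beyond the scatter.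

Compound 4 is therefore expected to give about 35000 nM, between 10000 nM and 120000 nM. That expectation means a step of a 3.7-fold higher number from compound 3 to compound 4 (0.56 log units; beyond the scatter), and the assay may well report only its limit.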

Compound 4, half-maximal inhibitory concentration: 41200 nM
Compound 4: the middle estimate sits 1.2-fold (0.07 log units) below what was measured; the measured number falls inside the stated range.
By their numbers in this assay, from the lowest: compound 3; then compound 2; then compound 4. At a limit, above all of these: compound 1.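

In this assay, putting diethylamino in place of (2-(pyrrolidin-1-yl)ethyl)amino on the aromatic carbon next to the ring nitrogen gives a 4.3-fold higher number from compound 3 to compound 4 (0.64 log units; beyond the scatter). This sets the side chain against a plain dialkylamino group with a measured number on both sides, which the earlier comparison could do only against a limit. The step from dimethylamino to diethylamino, an at least 1.2-fold lower number from compound 1 to compound 4 (0.08 log units; that floor lies within the scatter), cannot be read, because compound 1 stands at a limit: the limit of > 50000 nM in this assay, at which 1 of the 4 values shown sits.

The compounds shown leave open whether the difference follows the pyrrolidine ring, the chain or the hydrogen on the linking nitrogen. A (2-(diethylamino)ethyl)amino group, a morpholine in place of the pyrrolidine or a longer chain between the two nitrogens would begin to separate these.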